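The source may hold more compounds than are shown below. What is called first, only, known or untested is meant among the compounds shown, and "the series" means these compounds.

Measured in a functional assay on A549 cells (Homo sapiens) for inhibition, read by sulforhodamine B assay, with a stated time of 48 h, tested at 10 uM; on this read-out lower numbers stand for less inhibition of growth and higher numbers for more inhibition of growth at the one concentration tested:
- compound 1 `CC(=O)c1ccc(NC(=O)Cn2nc(-c3ccc(Cl)cc3)nc2N)cc1`: 22%
- compound 2 `C/C(=N/O)c1ccc(NC(=O)Cn2nc(C(F)(F)F)nc2N)cc1`: 29%
- compound 3 `C/C(=N/O)c1ccc(NC(=O)Cn2nc(-c3ccccc3)nc2N)cc1`: 32%

Compound 2, at 29%, stands among three numbers that sit close together, and both of the other compounds lie within the scatter of it. The next compound to be tested in this assay is compound 4 `CC(=O)c1ccc(NC(=O)Cn2nc(C(F)(F)F)nc2N)cc1`, which keeps the trifluoromethyl of compound 2 and changes one group: a group of 3 heavy atoms (2 carbon, 1 oxygen; no ring) in place of a group of 4 heavy atoms (2 carbon, 1 nitrogen, 1 oxygen; no ring), on an aromatic carbon. In words, a group of 3 heavy atoms, acetyl, takes the place of a group of 4 heavy atoms, on an aromatic carbon.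

Going by the values given here, no measured step covers this exchange. Among the compounds with values here, the only step available is a number 3 percentage points higher from compound 2 to compound 3 (within the scatter), and it concerns the other end of the molecule, so it shows only that one change in this small set left the number within the scatter. Compound 1 carries the acetyl too, but it also differs from compound 2 in a second place, so compound 1 at 22% is only a loose guide. It hints at a slightly lower number, if anything.

The expected change is small, with a number 3 percentage points lower from compound 2 to compound 4 (within the scatter) estimated and no shift beyond the scatter anticipated. For compound 4 the estimated value is 26%, with an expected range of 13% to 39%.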

Compound 4, percent growth inhibition at one concentration: 20%
Compound 4: middle estimate off by 6 percentage points, on the high side; the range from low to high includes it.
By their numbers in this assay, from the lowest: compounds 4, 1, 2 and 3 (each within the scatter of the next, the first and the last beyond it).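

In this assay, the exchange at this position, on an aromatic carbon para to a large group, can now be read directly: with the trifluoromethyl held fixed, acetyl in place of the group of 4 heavy atoms gives a number 9 percentage points lower from compound 2 to compound 4 (within the scatter) and so does not separate the two groups. The acetyl group has 0 hydrogen-bond donors and the group it replaces has 1, yet that difference in count comes with no step beyond the scatter in this pair. Going by these compounds alone, with acetyl held fixed, the other end of the molecule can also be read for the first time, and trifluoromethyl in place of 4-chlorophenyl gives a number 2 percentage points lower from compound 1 to compound 4 (within the scatter) and likewise leaves the two compounds inseparable. Nothing measured here bears on why these numbers fall as they do.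

The compounds shown leave open whether an amine or a carboxylic acid at this position on the aromatic carbon would move the number beyond the scatter. They also leave open whether a longer chain in place of the trifluoromethyl would do so, with either acetyl or the group of 4 heavy atoms in place.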